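A Pentyl Chain Tail Swapped for a Cyclopentylethyl Tail

The compounds below may be only part of what the source reports. "The series", "measured", "known", "first", "only" and "open" are said of these compounds alone.

Compound 1 `O=C(Nn1c(-c2cccc([N+](=O)[O-])c2)nc2c(-c3ccc(Cl)cc3)n[nH]c2c1=O)c1ccccc1`: 18500 nM
Compound 2 `CCCCCc1nc2c(-c3ccc(Cl)cc3)n[nH]c2c(=O)n1NC(=O)c1ccccc1`: 2260 nM

Among the measured compounds shown here, in a functional assay on HT-29 cells (Homo sapiens) for inhibition, read by MTT assay, with a stated time of 2 days (on this read-out lower numbers stand for stronger inhibition of growth and higher numbers for weaker inhibition of growth), compound 2 gives 2260 nM, the lowest of the two numbers measured so far. Compound 1 gives 18500 nM. For the measured compounds named here, the only measured step is an 8.2-fold lower number from compound 1 to compound 2 (0.91 log units; beyond the scatter), which came with pentyl in place of 3-nitrophenyl on an aromatic carbon.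

Compound 3 `O=C(Nn1c(CCC2CCCC2)nc2c(-c3ccc(Cl)cc3)n[nH]c2c1=O)c1ccccc1` is the next member of the series. It differs from compound 2 by cyclopentyl in place of propyl on a saturated chain carbon, two bonds along the chain from an aromatic carbon. Going by the values given here, the one measured step exchanged an aromatic ring for a saturated chain, whereas this change keeps a saturated chain and only turns its far end into a non-aromatic ring; that step therefore gives no direct guidance. Among the compounds with values here, with no closer precedent, a step of no size beyond the usual scatter is expected. Compound 3 is expected to give 2000 nM, within a range of 700 nM to 6000 nM. The expected step is a 1.1-fold lower number from compound 2 to compound 3 (0.05 log units; within the scatter).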

Compound 3, concentration for 50% growth inhibition: 1800 nM
Compound 3: the middle estimate sits 1.1-fold (0.05 log units) above what was measured; the measured number falls inside the stated range.
By their numbers in this assay, from the lowest: compounds 3 and 2 (each within the scatter of the next); then compound 1.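

In this assay the step from the open pentyl chain to the ring-ended tail reads a 1.3-fold lower number from compound 2 to compound 3 (0.10 log units; within the scatter), so at this place on the saturated chain, cyclopentyl can stand in for propyl without moving the number beyond the scatter. The comparison with the aromatic tail reads a 10-fold lower number from compound 1 to compound 3 (1.01 log units; beyond the scatter), which gives a second saturated tail, after the pentyl of compound 2, with a number well under that of the 3-nitrophenyl compound 1. No measurement shown explains either result.

As far as these compounds go, an amine or a carboxylic acid at the far end of the chain remains open, as does a longer chain or a cyclohexyl ring in place of cyclopentyl. With only one aromatic tail shown, it is also unclear how far the gap to compound 1 applies to aromatic tails in general.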